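Methyl to chloro on the anilide ring of compound 3

The compounds below may be only part of what the source reports. "The series", "measured", "known", "first", "only" and "open" are said of these compounds alone.

Three compounds of the shared core have numbers in a functional assay on K562 cells (Homo sapiens) for antiproliferative activity (on this read-out higher numbers stand for weaker inhibition and lower numbers for stronger inhibition), so far. Compound 1 `Cc1ncn(-c2cc(NC(=O)c3ccc(C)c(Nc4nc(-c5cccnc5)cs4)c3)cc(C(F)(F)F)c2)n1` gives 1630 nM; compound 2 `Cc1ccc(C(=O)Nc2cc(-c3cnn(C)c3)cc(C(F)(F)F)c2)cc1Nc1nc(-c2cccnc2)cs1` gives 5380 nM; compound 3 `Cc1cc(NC(=O)c2ccc(C)c(Nc3nc(-c4cccnc4)cs3)c2)cc(-n2cnc(C)c2)c1` gives 3290 nM. Compound 3 stands second highest of the three: its nearest neighbour is compound 2, whose number lies within the scatter of that of compound 3, while compound 1 lies furthest, with a number beyond the scatter below that of compound 3.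

The step to compound 4 `Cc1cn(-c2cc(Cl)cc(NC(=O)c3ccc(C)c(Nc4nc(-c5cccnc5)cs4)c3)c2)cn1` is chloro in place of methyl on an aromatic carbon, on an aromatic carbon of a six-membered aromatic ring of carbon only, meta to a 4-methyl-1H-imidazol-1-yl group and meta to a large group. The only measured step among these compounds, a 3.3-fold higher number from compound 1 to compound 2 (0.52 log units; beyond the scatter), concerns the exchange of one azole for another at a different place and so does not bear on a methyl-to-chloro swap. With no step of this kind in hand, no movement beyond the scatter is expected in this assay.

Compound 4 is therefore estimated at 3000 nM, within a range of 1200 nM to 7500 nM, the expected step being a 1.1-fold lower number from compound 3 to compound 4 (0.04 log units; within the scatter).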

Compound 4, half-maximal inhibitory concentration: 2360 nM
The estimate for compound 4 lay 1.3-fold (0.10 log units) above the measured number; low and high end bracket the measured number.
By their numbers in this assay, from the lowest: compounds 1, 4, 3 and 2 (each within the scatter of the next, the first and the last beyond it).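

In this assay, chloro in place of methyl on the aromatic carbon meta to the 4-methyl-1H-imidazol-1-yl group gives a 1.4-fold lower number from compound 3 to compound 4 (0.14 log units; within the scatter) and so does not separate the two groups at this position. Among the compounds shown here, this is the first direct reading of a change at this carbon, whereas the only earlier step, a 3.3-fold higher number from compound 1 to compound 2 (0.52 log units; beyond the scatter), exchanged one azole for another at a different place and left this position untouched. No measurement to hand bears on why methyl and chloro read alike here.

Going by these compounds, the reading covers only methyl and chloro on this carbon with the 4-methyl-1H-imidazol-1-yl group in place, so the outcome with an amine, a methoxy group or a carboxylic acid at the same carbon stays open. Also open, on these data alone, are a direct step from methyl or chloro to trifluoromethyl with that imidazole held fixed, and whether the methyl-to-chloro swap reads the same alongside 3-methyl-1H-1,2,4-triazol-1-yl or 1-methyl-1H-pyrazol-4-yl.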